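Chloro for trifluoromethyl on the benzylamine arm

The compounds below may be only part of what the source reports. "The series", "measured", "known", "first", "only" and "open" are said of these compounds alone.

Measured so far:
compound 1, `COc1cnc(-c2ccccn2)nc1NCc1ccccc1C(F)(F)F`, 555 mL/min/kg
compound 2, `COc1cnc(-c2ccccn2)nc1C1CCCC1`, > 1000 mL/min/kg

The series shares one core and varies the group on the pyrimidine amine carbon. Within the data shown here, in an in vitro ADME assay on microsomes from liver (Rattus norvegicus) for metabolic stability, read by LC-MS, tested at 0.05 uM (on this read-out lower numbers stand for slow clearance and higher numbers for fast clearance), compound 1 gives 555 mL/min/kg, the only plain number among the two results. Compound 2 reaches the limit of this assay, > 1000 mL/min/kg, which is a bound and not a number; (the limit of > 1000 mL/min/kg in this assay, at which 1 of the 2 values shown sits). Compound 1 therefore stands as the one reference point with a measured value, and nothing measured yet sits on the slow side of it.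

Compound 3, `COc1cnc(-c2ccccn2)nc1NCc1ccccc1Cl`, is the next member to be measured. It differs from compound 1 by chloro in place of trifluoromethyl on an aromatic carbon. Among the measured compounds shown here, no step between measured compounds touches this position, so no size can be read off for it. In this assay the step is expected to be small, with no clear direction beyond the scatter. The implied step, a 1.1-fold lower number from compound 1 to compound 3 (0.05 log units; within the scatter), is an expectation only. Compound 3 is expected at 500 mL/min/kg, within 250 mL/min/kg to 1000 mL/min/kg.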

Compound 3, clearance: 827 mL/min/kg
Estimate against measurement, compound 3: 1.7-fold (0.22 log units) below, and the stated range covers the measured number.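

In this assay, among these compounds, the exchange of trifluoromethyl for chloro on an aromatic carbon, ortho to a large group, gives a 1.5-fold higher number from compound 1 to compound 3 (0.17 log units; within the scatter) and provides the first sized step at this position. The four heavy atoms of trifluoromethyl give way to the single chlorine, and this pair cannot be told apart in the clearance read-out, so the exchange offers no route to a slower-clearing compound, and the data give no cause for the small difference in the printed numbers. Compound 3 gives a plain number and not a bound, so this step can be sized, while the set still holds one result that is only a limit of the assay: the limit of > 1000 mL/min/kg in this assay, at which 1 of the 3 values shown sits.

One exchange on one carbon of the benzylamine arm cannot show whether this position is generally insensitive, so a methoxy group, a nitrile, a fluorine or an amine at the same place could still give a step beyond the scatter in this assay. Also open, going by these compounds, are a carboxylic acid on the same ring and a longer chain between the amine and the ring, each of which would test a different part of the arm while the shared core stays fixed.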